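Urea-to-amide change on the methoxy series

This account rests on a few compounds, and the source may have more. Where it says the series, first, only, none or still open, it means among the compounds named here.

Compound 3 `COc1cc(Cl)cc(-c2nn(-c3cccc(NC(=O)Nc4ccc(Cl)c(Cl)c4)c3)cc2-c2ccncc2)c1` is the weakest of the three measured compounds in a functional assay on NCI-H322M cells (Homo sapiens) for inhibition, read by sulforhodamine B assay, with a stated time of 48 h, tested at 1 uM (a higher number here means a weaker effect of the compound at the concentration tested, a lower number a stronger effect), where compound 3 gives 88%. Compound 1 `O=C(Nc1cccc(-n2cc(-c3ccncc3)c(-c3cc(O)cc(Cl)c3)n2)c1)Nc1ccc(Cl)c(Cl)c1` gives 59%, and compound 2 `COc1cc(Cl)cc(-c2nn(-c3cccc(NC(=O)Nc4cc(C(F)(F)F)cc(C(F)(F)F)c4)c3)cc2-c2ccncc2)c1` gives 49%; both numbers lie beyond the scatter below that of compound 3. Within the data shown here, the only single-point step measured so far is a number 29 percentage points higher from compound 1 to compound 3 (beyond the scatter), which concerns a methyl in place of hydrogen on an oxygen on an aromatic ring and says nothing about the carbonyl end of the molecule.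

Compound 4 `COc1cc(Cl)cc(-c2nn(-c3cccc(NC(=O)c4cccc(C(F)(F)F)c4)c3)cc2-c2ccncc2)c1` differs from compound 3 at that end: 3-(trifluoromethyl)phenyl in place of (3,4-dichlorophenyl)amino on a carbonyl carbon. Among the measured compounds shown here, no measured step bears on this change; the comparison between compound 2 and compound 3 involves the terminal aromatic ring but keeps the urea intact. The expectation is therefore loose. Given that compound 3 sits at the top of the range and the other two compounds lie well below, compound 4 is estimated to give 70% (range 45% to 95%) in this assay, a step of a number 18 percentage points lower from compound 3 to compound 4 (beyond the scatter) that is expected to point downward but cannot be called more than tentative.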

Compound 4, a percentage reported as activity, at one concentration (the size of the read-out at that concentration, not a potency): 90%
Compound 4: the middle estimate sits 20 percentage points below what was measured; the range from low to high includes it.
By their numbers in this assay, from the lowest: compounds 2 and 1 (each within the scatter of the next); then compounds 3 and 4 (each within the scatter of the next).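

In this assay, the exchange of (3,4-dichlorophenyl)amino for 3-(trifluoromethyl)phenyl on the carbonyl carbon gives a number 2 percentage points higher from compound 3 to compound 4 (within the scatter). Among these compounds, this is the first single-place step at the carbonyl end of the methoxy series, and it shows that turning the urea into an amide, which removes the hydrogen-bond donor counted on the leaving group, does not move the read-out beyond the scatter. No measurement available here explains this outcome.

As far as these compounds go, it remains open whether the amide change would read the same way on the hydroxy compound 1 or with the terminal ring of compound 2, where the urea read-out is lower. Also open, from the compounds shown here alone, is how a morpholine or a piperazine on the same carbonyl carbon would read at this position.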